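Enaminone ketone aryl swap on the dimethoxy core

The compounds below may be only part of what the source reports. "The series", "measured", "known", "first", "only" and "open" are said of these compounds alone.

Measured so far:
compound 1 `COc1cc(OC)c2sc(-c3ccc(N/C=C\C(=O)c4cc(OC)c(OC)c(OC)c4)cc3)nc2c1` — 21800 nM
compound 2 `COc1ccc2nc(-c3ccc(N/C=C\C(=O)c4ccc(OC)c(F)c4)cc3)sc2c1` — 900 nM
compound 3 `COc1ccc(C(=O)/C=C\Nc2ccc(-c3nc4cc(OC)c(OC)c(OC)c4s3)cc2)cc1O` — 23000 nM

In a functional assay on A549 cells (Homo sapiens) for antiproliferative activity, read by sulforhodamine B assay, with a stated time of 48 h (on this read-out higher numbers stand for weaker inhibition and lower numbers for stronger inhibition), compound 1 gives 21800 nM, the second highest of the three numbers. Compound 3 sits within the scatter of it, so no order between the two can be read. Compound 2 shows a far lower number, beyond the scatter. Compound 4 `COc1cc(OC)c2sc(-c3ccc(N/C=C\C(=O)c4ccc(OC)c(F)c4)cc3)nc2c1` keeps the core of compound 1 and carries the change (3-fluoro-4-methoxyphenyl in place of 3,4,5-trimethoxyphenyl on a carbonyl carbon). The ketone aryl group that enters is the one present in compound 2, whose value in this assay is the lowest shown, while the core is not that of compound 2, so no direct step is known. A sizeable fall is expected, a 7.3-fold lower number from compound 1 to compound 4 (0.86 log units; beyond the scatter), short of the number of compound 2. Compound 4 is expected at 3000 nM, between 800 nM and 12000 nM.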

Compound 4, half-maximal inhibitory concentration: 5300 nM
For compound 4 the middle estimate is 1.8-fold (0.25 log units) below the measured one, and the stated range covers the measured number.
By their numbers in this assay, from the lowest: compound 2; then compound 4; then compounds 1 and 3 (each within the scatter of the next).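

On the core of compound 1, 3-fluoro-4-methoxyphenyl in place of 3,4,5-trimethoxyphenyl on a carbonyl carbon gives a 4.1-fold lower number from compound 1 to compound 4 (0.61 log units; beyond the scatter) in this assay with nothing else altered. Among these compounds, this is the only single-place step so far, and it shows that the ketone aryl group alone moves the number beyond the scatter on this core. Nothing available bears on the cause of the step. Still open, going by these compounds, is how an unsubstituted phenyl or a pyridine ring on the carbonyl carbon would compare.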